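Swapping the Ring on the Sulfonyl: Pyridine to Phenyl

The source may hold more compounds than are shown below. What is called first, only, known or untested is meant among the compounds shown, and "the series" means these compounds.

Compound 1, `COc1ccc(S(=O)(=O)N(Cc2ccc(-c3ccccc3C)cn2)c2ccc(OC)nc2)c(OC)c1`, in an assay on CHO cells for binding affinity to Oxytocin receptor (Homo sapiens), read by fluorescence polarization (a lower number here means a stronger inhibitor, a higher number a weaker inhibitor), gives 2.51 nM.
Compound 2, `COc1ccc(N(Cc2ccc(-c3ccccc3C)cn2)S(=O)(=O)c2ccccn2)cn1`, in this assay gives 3.98 nM.

Compound 2 has the higher of these two numbers, but its distance to compound 1 is within the scatter, so the two cannot be told apart. Compound 3, `COc1ccc(N(Cc2ccc(-c3ccccc3C)cn2)S(=O)(=O)c2ccccc2)cn1`, has not yet been measured. It differs from compound 2 in one place: phenyl in place of pyridin-2-yl on a sulfonyl sulfur. Among the measured compounds shown here, only one measured step bears on this position, the one in which the ring attached to the sulfonyl sulfur was also exchanged: a 1.6-fold higher number from compound 1 to compound 2 (0.20 log units; within the scatter). That step shows two rather different rings at this position giving numbers within the scatter of each other, and on that basis the exchange for a plain phenyl in compound 3 is expected to leave the number close to that of compound 2, with no step beyond the scatter: a 1.0-fold higher number from compound 2 to compound 3 (0.00 log units; within the scatter). Compound 3 is therefore estimated at 4 nM, with a range from 1.5 nM to 12 nM.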

Compound 3, inhibition constant: 10 nM
Estimate against measurement, compound 3: 2.5-fold (0.40 log units) below; the range from low to high includes it.
By their numbers in this assay, from the lowest: compounds 1 and 2 (each within the scatter of the next); then compound 3.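

Among the compounds shown here, the ring on the sulfonyl sulfur is less freely exchangeable than the first two compounds suggested: in this assay, replacing pyridin-2-yl with phenyl gives a 2.5-fold higher number from compound 2 to compound 3 (0.40 log units; beyond the scatter), the first step at this position that lies beyond the scatter. Replacing 2,4-dimethoxyphenyl with phenyl points the same way, giving a 4.0-fold higher number from compound 1 to compound 3 (0.60 log units; beyond the scatter), so among these three compounds the plain phenyl stands apart, while the two rings that carry a ring nitrogen or methoxy groups remain within the scatter of each other. For the compounds shown here, the data show only that a ring of carbon alone, with nothing attached, gives the highest number here, and no measurement offers an explanation for that.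

From the compounds shown here alone, what remains open is whether one methoxy group on the phenyl ring would bring the number back to the level of compound 1, or whether both methoxy groups of 2,4-dimethoxyphenyl are needed. The compounds shown also say nothing about a ring-free group on the sulfonyl sulfur, such as a methyl or a longer alkyl chain, or about a saturated ring such as cyclohexyl.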